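Swapping the aryl group on the shared core

A few compounds are considered here, and "the series" means these few. Any claim that something is new, unique, unknown or untested is made for them only; others in the source may bear on it.

Compound 2 `Cc1nc(C)n(CC(=O)N2CCN(c3sc(C(F)(F)F)nc3-c3cnc(N4CCCC4)nc3)C[C@H]2C)n1` gives 523 nM in a functional assay on U2OS cells for antagonist activity at C-X-C chemokine receptor type 3 (Homo sapiens), read by beta-arrestin recruitment; on this read-out lower numbers stand for stronger inhibition and higher numbers for weaker inhibition. Compound 1 `CCc1ncc(-c2nc(C(F)(F)F)sc2N2CCN(C(=O)Cn3nc(C)nc3C)[C@H](C)C2)cn1` gives 1430 nM.

Going by the values given here, compound 2 stands lowest of the two numbers; the only other value, from compound 1, sits a clear step higher. Compound 3 `Cc1nc(C)n(CC(=O)N2CCN(c3sc(C(F)(F)F)nc3-c3ccc(C(F)(F)F)nc3)C[C@H]2C)n1` differs from compound 2 in one place: 6-(trifluoromethyl)pyridin-3-yl in place of 2-(pyrrolidin-1-yl)pyrimidin-5-yl on an aromatic carbon. Among the compounds with values here, the one measured step, a 2.7-fold lower number from compound 1 to compound 2 (0.44 log units; beyond the scatter), shows that taking away the pyrrolidin-1-yl on that ring raises the number. Compound 3 loses that group, and nothing measured speaks to the trifluoromethylpyridine that replaces it. The expected step is therefore a 2.9-fold higher number from compound 2 to compound 3 (0.46 log units; beyond the scatter), a higher number. Compound 3 is expected to give about 1500 nM, within 500 nM to 4500 nM.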

Compound 3, half-maximal inhibitory concentration: 608 nM
Beside the measured number, compound 3's estimate is 2.5-fold (0.39 log units) above it; measured number inside the range.
By their numbers in this assay, from the lowest: compounds 2 and 3 (each within the scatter of the next); then compound 1.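

The pyrrolidin-1-yl group is not required at this position: with a 1.2-fold higher number from compound 2 to compound 3 (0.07 log units; within the scatter) in this assay, a 6-(trifluoromethyl)pyridin-3-yl group does as well as the 2-(pyrrolidin-1-yl)pyrimidin-5-yl group. The same replacement also improves on the 2-ethylpyrimidin-5-yl group, with a 2.4-fold lower number from compound 1 to compound 3 (0.37 log units; beyond the scatter), so very different groups can reach this level. No measured evidence here explains why these two groups match.

Still open, from the compounds shown here alone, is whether a morpholine in place of pyrrolidin-1-yl on the pyrimidine, or a nitrile in place of trifluoromethyl on the pyridine, would give a lower number.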